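This account rests on a few compounds, and the source may have more. Where it says the series, first, only, none or still open, it means among the compounds named here.

Series notes. Four compounds share a common core and were, or are to be, read in a functional assay on the whole organism (artery, strain albino) with Rattus norvegicus as the target, with a stated time of 900 min, at a dose of 10 mg/kg by the oral route; a higher number here means more inhibition at the dose given (going by the name of the read-out), a lower number less inhibition. Compound 1 `CC1=C(C(=O)Nc2ccc(F)cc2)C(c2ccc([N+](=O)[O-])cc2)N=C(SCc2cccc(Cl)c2)N1` gives 10.8%, and compound 2 `CC1=C(C(=O)Nc2ccc(F)cc2)C(c2ccc([N+](=O)[O-])cc2)N=C(SCc2ccc(Cl)cc2)N1` gives 16.9%. The change between them, (4-chlorophenyl in place of 3-chlorophenyl on a saturated chain carbon bound to a sulfur), gave a number 6.1 percentage points higher from compound 1 to compound 2 (within the scatter). Compound 3 `CC1=C(C(=O)Nc2ccc([N+](=O)[O-])cc2)C(c2cccc([N+](=O)[O-])c2)N=C(SCc2cccc(Cl)c2)N1` gives 10.8%, level with compound 1 at the digits shown. The difference between the core of compound 1 and the core of compound 3 is not broken down here. Compound 4 `CC1=C(C(=O)Nc2ccc([N+](=O)[O-])cc2)C(c2cccc([N+](=O)[O-])c2)N=C(SCc2ccc(Cl)cc2)N1` is not yet measured; it carries the same change as before, (4-chlorophenyl in place of 3-chlorophenyl on a saturated chain carbon bound to a sulfur), now on the core of compound 3. Because the measured pair showed a number 6.1 percentage points higher from compound 1 to compound 2 (within the scatter), a step of similar size is expected, a number 5.2 percentage points higher from compound 3 to compound 4 (within the scatter). For compound 4 the estimate in this assay is 16%, expected to fall between 6% and 26%.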

Compound 4, a percentage reported as inhibition, in the whole organism at one dose (the size of the read-out at that dose, not a potency): 12.3%
Compound 4: the middle estimate sits 3.7 percentage points above what was measured; low and high end bracket the measured number.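

In this assay, 4-chlorophenyl in place of 3-chlorophenyl on a saturated chain carbon bound to a sulfur gives a number 1.5 percentage points higher from compound 3 to compound 4 (within the scatter). Set beside the step on the core of compound 1, the result does not distinguish the two cores: the same change on two cores in this assay, a number 6.1 percentage points higher (within the scatter) from compound 1 to compound 2 and a number 1.5 percentage points higher (within the scatter) from compound 3 to compound 4, 4.6 percentage points apart, within the scatter of two such steps. The change therefore carries across these two cores without a detectable difference, but this does not show that it has a real effect on either core, nor does it say how it would behave on any other core.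

The compounds shown leave open what an amine or a carboxylic acid in place of the chlorine would give, or a longer chain in place of the chlorobenzyl group. They also do not separate the individual differences between the core of compound 1 and the core of compound 3.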